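Hydrazone ureas: amine swap on the benzhydrylidene series

The compounds below may be only part of what the source reports. "The series", "measured", "known", "first", "only" and "open" are said of these compounds alone.

Measured so far:
compound 1 `C/C(=N\NC(=O)Nc1nc2ccc(CN3CCC(C)CC3)cc2s1)c1cnccn1` — 11800 nM
compound 2 `CN(C)Cc1ccc(NC(=O)NN=C(c2ccccc2)c2ccccc2)cc1` — 12100 nM

In a functional assay on MCF7 cells (Homo sapiens) for antiproliferative activity, read by CCK-8 assay, with a stated time of 24 h (a higher number here means a weaker inhibitor, a lower number a stronger inhibitor), compound 2 gives 12100 nM, the higher of the two numbers in hand; compound 1 gives 11800 nM, and the two values lie within the scatter of each other, so no order between them is claimed. Compound 3 `CC1CCN(Cc2ccc(NC(=O)NN=C(c3ccccc3)c3ccccc3)cc2)CC1` is not yet measured. It differs from compound 2 in one place: 4-methylpiperidin-1-yl in place of dimethylamino on a saturated chain carbon bound to an aromatic carbon. The same group, as (4-methylpiperidin-1-yl)methyl, is also present in compound 1, which on a different core sits at a value close to that of compound 2. Among the compounds with values here, no measured pair isolates this change, so the expectation rests on the two weak values alone. The step from compound 2 to compound 3 is expected to be small, a 1.1-fold lower number from compound 2 to compound 3 (0.04 log units; within the scatter), with no direction beyond the scatter. Compound 3 is accordingly estimated at 11000 nM, within 4000 nM to 30000 nM.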

Compound 3, half-maximal inhibitory concentration: 13300 nM
Beside the measured number, compound 3's estimate is 1.2-fold (0.08 log units) below it, within the range that was stated.
By their numbers in this assay, from the lowest: compounds 1, 2 and 3 (each within the scatter of the next).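

In this assay, 4-methylpiperidin-1-yl in place of dimethylamino on a saturated chain carbon bound to an aromatic carbon gives a 1.1-fold higher number from compound 2 to compound 3 (0.04 log units; within the scatter). Within the data shown here, on this core, the position therefore takes a ring-bearing amine in place of an open-chain one with no change beyond the scatter, and this is the first direct reading of the swap, which compound 1 on its different core could not give. The compounds carry no measurement that bears on the reason for this flat step.

From the compounds shown here alone, whether any group at this position moves the number beyond the scatter remains open, for example morpholin-4-yl, a primary amine, a carboxylic acid or a longer chain carrying the amine. Also open, going by these compounds, is whether dimethylamino in place of 4-methylpiperidin-1-yl on the core of compound 1 would read the same way.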